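A few compounds are considered here, and "the series" means these few. Any claim that something is new, unique, unknown or untested is made for them only; others in the source may bear on it.

Measured compounds in an assay on membranes from lung (Cavia porcellus) for binding affinity to cysteinyl leukotriene receptor (Homo sapiens); a lower number here means a stronger inhibitor, a higher number a weaker inhibitor:

Compound 1 `CCCC(CCC(=O)O)Cc1ccc(OCc2ccc3ccccc3n2)cc1`, 21 nM
Compound 2 `CC(CCc1nnn[nH]1)Cc1ccc(OCc2ccc3ccccc3n2)cc1`, 12 nM
Compound 3 `CC(CCc1nnn[nH]1)Cc1cccc(OCc2ccc3ccccc3n2)c1`, 34 nM

Compound 2 and compound 3 are built from the same atoms joined differently; the difference between the two cores is not broken down here. Compound 3 stands at the highest number of the three, with compound 1 within the scatter of it and compound 2 beyond it.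

One change occurs twice in the set. From compound 2 to compound 1 it is 1-(2-carboxyethyl)butyl in place of 3-(1H-tetrazol-5-yl)-1-methylpropyl on a saturated chain carbon bound to an aromatic carbon, and the step was a 1.8-fold higher number from compound 2 to compound 1 (0.24 log units; within the scatter). Compound 4 `CCCC(CCC(=O)O)Cc1cccc(OCc2ccc3ccccc3n2)c1` is not yet measured; it arises from compound 3 by the same change, (1-(2-carboxyethyl)butyl in place of 3-(1H-tetrazol-5-yl)-1-methylpropyl on a saturated chain carbon bound to an aromatic carbon), at the same place.

Among the compounds with values here, for compound 4 a step of about a 1.8-fold higher number from compound 3 to compound 4 (0.25 log units; within the scatter) is expected in this assay, resting on the single earlier instance, because the step of a 1.8-fold higher number from compound 2 to compound 1 (0.24 log units; within the scatter) was small and within the scatter. Since the starting point, compound 3, gives 34 nM, compound 4 is estimated at 60 nM, expected to fall between 25 nM and 150 nM.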

Compound 4, inhibition constant: 50 nM
Compound 4: the middle estimate sits 1.2-fold (0.08 log units) above what was measured; low and high end bracket the measured number.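

Placing 1-(2-carboxyethyl)butyl in place of 3-(1H-tetrazol-5-yl)-1-methylpropyl gives a 1.5-fold higher number from compound 3 to compound 4 (0.17 log units; within the scatter) in this assay, and this step agrees with the earlier one: the same change on two cores in this assay, a 1.8-fold higher number (0.24 log units; within the scatter) from compound 2 to compound 1 and a 1.5-fold higher number (0.17 log units; within the scatter) from compound 3 to compound 4, 1.2-fold (0.08 log units) apart, within the scatter of two such steps

On these two cores, then, the change carries over, and on neither does it produce a step beyond the scatter. This does not show that the change would stay as small on any other core, and it gives no reason why the two steps agree.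

The change alters both the acidic end group and the chain carrying it, so the compounds shown do not separate the two contributions; a carboxylic acid on the chain of 3-(1H-tetrazol-5-yl)-1-methylpropyl, or the tetrazole on the chain of 1-(2-carboxyethyl)butyl, would address that. Also open, going by these compounds, is how an amide or an amine in place of the carboxylic acid would fare on either core.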